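Chain Length at the Quaternary Carbon of a Pyrrolidine Core

This account rests on a few compounds, and the source may have more. Where it says the series, first, only, none or still open, it means among the compounds named here.

Measured compounds:
Compound 1, `CCCCCCCCC[C@]1(CO)NC[C@@H](O)[C@@H]1O`, gives 0%.
Compound 2, `COc1ccc([C@]2(CO)NC[C@@H](O)[C@@H]2O)cc1`, gives 2.7%.
Compound 3, `C[C@]1(CO)NC[C@@H](O)[C@@H]1O`, gives 10.9%.

In an assay on isolated protein for inhibition of tissue alpha-L-fucosidase (Bos taurus), tested at 1000 uM (on this read-out higher numbers stand for more inhibition at the one concentration tested (going by the name of the read-out) and lower numbers for less inhibition), compound 3 stands highest of the three numbers. Its nearest neighbour is compound 2, whose value lies lower by an amount within the scatter, so no order between compound 3 and compound 2 can be claimed. Its furthest neighbour is compound 1, whose value lies lower by an amount beyond the scatter; compound 1 carries the longest chain of the three at the same carbon.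

Compound 4, `CCCC[C@]1(CO)NC[C@@H](O)[C@@H]1O`, has not yet been measured in this assay. It differs from compound 3 by propyl in place of hydrogen on a saturated chain carbon bound to a saturated ring carbon.

Among the measured compounds shown here, no measured step between compounds differing in a single place is available. Compound 4 carries a chain of middle length between the methyl of compound 3 and the nonyl of compound 1, and the step is expected to be small and downward, because compound 1 gives 0% while compound 3 gives 10.9%. The estimated step for compound 4 is a number 5.9 percentage points lower from compound 3 to compound 4 (within the scatter). Compound 4 is expected to give 5%, within a range from 0% to 14%.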

Compound 4, a percentage reported as inhibition, at one concentration (the size of the read-out at that concentration, not a potency): 20.8%
For compound 4 the middle estimate is 15.8 percentage points below the measured one; the whole stated range lies below it.
By their numbers in this assay, from the lowest: compounds 1, 2, 3 and 4 (each within the scatter of the next, the first and the last beyond it).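

In this assay, among the compounds shown here, shortening the nonyl chain to the butyl chain gives a number 20.8 percentage points higher from compound 1 to compound 4 (beyond the scatter) on the shared core, the only single-place change here that lies beyond the scatter, so the length of the chain on this saturated ring carbon can matter for the read-out. Going from methyl to butyl gives a number 9.9 percentage points higher from compound 3 to compound 4 (within the scatter) and leaves compound 3 and compound 4 without an order, so no gain from lengthening the methyl chain can be claimed, and the contrast so far rests on the nonyl chain of compound 1 alone. Nothing available explains the chain's bearing on inhibition at this position.

The compounds shown leave open how inhibition behaves on chains of lengths between butyl and nonyl, such as hexyl or octyl, and so where along that span it is lost. They also leave open whether a hydroxyl, an amine or a carboxylic acid at the end of the butyl chain, or a plain phenyl ring in its place, would keep the read-out of compound 4 or move it.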